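Swapping cyclohexyl for isobutyl on a bombesin receptor agonist

The source may report more compounds than this note shows. Statements on the series, on what has been measured and on what is new or still open speak of the compounds shown alone.

Measured compounds:
Compound 1 `O=C(O)c1ccccc1-c1ccc(CCc2ncc(CC3CCCCC3)[nH]2)cc1` — 41 nM
Compound 2 `CC(C)(C)CCc1cnc(CCc2ccc(-c3ccccc3C(=O)O)cc2)[nH]1` — 39 nM
Compound 3 `Cc1ccc(Cc2cnc(CCc3ccc(-c4ccccc4C(=O)O)cc3)[nH]2)cc1` — 2660 nM

All three share one core and differ only in the group attached on a saturated chain carbon bound to an aromatic carbon. In an in vitro functional assay on cells for agonist activity at Bombesin receptor subtype-3 (Homo sapiens), read by luminescence and calcium flux (a lower number here means that less compound is needed, a higher number that more compound is needed for the effect), compound 1 gives 41 nM and stands second highest of the three numbers. Its nearest neighbour is compound 2: a 1.1-fold lower number from compound 1 to compound 2 (0.02 log units; within the scatter). Its furthest is compound 3: a 65-fold higher number from compound 1 to compound 3 (1.81 log units; beyond the scatter). The same picture appears in a 68-fold higher number from compound 2 to compound 3 (1.83 log units; beyond the scatter): a saturated group, whether a ring or a branched chain, gives a low number, while 4-methylphenyl gives a much higher one.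

Compound 4 `CC(C)CCc1cnc(CCc2ccc(-c3ccccc3C(=O)O)cc2)[nH]1` is not yet measured. It differs from compound 1 as follows: isobutyl in place of cyclohexyl on a saturated chain carbon bound to an aromatic carbon. Isobutyl, like neopentyl, is a branched saturated chain with no ring, so the step from compound 1 to compound 2 bears most on it, and that step stayed within the scatter. Isobutyl is, however, smaller than either cyclohexyl or neopentyl, and no measured compound shows what a shorter chain does here. A small rise in the number, near the edge of the scatter, is therefore expected: a 2.0-fold higher number from compound 1 to compound 4 (0.29 log units; within the scatter). Compound 4 is estimated to give 80 nM in this assay, between 30 nM and 250 nM.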

Compound 4, half-maximal effective concentration: 119 nM
Beside the measured number, compound 4's estimate is 1.5-fold (0.17 log units) below it; the range from low to high includes it.
By their numbers in this assay, from the lowest: compounds 2 and 1 (each within the scatter of the next); then compound 4; then compound 3.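

Within the saturated groups, the size and shape of the group at this position do matter: in this assay, isobutyl in place of cyclohexyl is a modest step (a 2.9-fold higher number from compound 1 to compound 4 (0.46 log units; beyond the scatter)), even though neopentyl and cyclohexyl could not be told apart. Removing a single methyl from the neopentyl group gives a step of similar size (a 3.1-fold higher number from compound 2 to compound 4 (0.48 log units; beyond the scatter)), so the effect of that one methyl can be read directly, and it lies beyond the scatter. Isobutyl still stays far from 4-methylphenyl (a 22-fold lower number from compound 3 to compound 4 (1.35 log units; beyond the scatter)), which means that the large rise seen with 4-methylphenyl is not matched by any of the three saturated groups, although the reason for these differences remains unknown from the information available here.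

Going by these compounds, it remains open whether a straight chain such as n-pentyl, or a smaller ring such as cyclopentyl, would behave like cyclohexyl and neopentyl or like isobutyl. Also open, on these data alone, is whether plain phenyl would give a number as high as 4-methylphenyl does, and whether an amine or an ether oxygen could be placed in this chain.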